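Estimating clearance for compound 3

The source may report more compounds than this note shows. Statements on the series, on what has been measured and on what is new or still open speak of the compounds shown alone.

In an in vitro ADME assay on microsomes from liver (Homo sapiens) for metabolic stability (on this read-out higher numbers stand for fast clearance and lower numbers for slow clearance), compound 1 (`O=c1ccn(CCCCNC(c2ccccc2)(c2ccccc2)c2ccccc2)c(=O)[nH]1`) gives 64 mL.min-1.g-1 and compound 2 (`O=c1ccn(CCCCO[Si](c2ccccc2)(c2ccccc2)c2ccccc2)c(=O)[nH]1`) gives 69 mL.min-1.g-1, so compound 2 stands level with compound 1 within the usual scatter of repeat measurements. Compound 3 (`O=c1ccn(CCCCCCO[Si](c2ccccc2)(c2ccccc2)c2ccccc2)c(=O)[nH]1`) differs from compound 2 in one place: a group of 10 heavy atoms (6 carbon, 2 nitrogen, 2 oxygen; one six-membered aromatic ring with 2 hetero atoms) in place of a group of 8 heavy atoms (4 carbon, 2 nitrogen, 2 oxygen; one six-membered aromatic ring with 2 hetero atoms), on a saturated chain carbon, four bonds along the chain from an oxygen on an unsaturated carbon. Within the data shown here, no measured pair yet shows what a change of this kind does in this assay, so any forecast here is a judgement. A small rise is expected, and the estimated step of a 1.2-fold higher number from compound 2 to compound 3 (0.09 log units; within the scatter) stays within the scatter. Compound 3 is expected to give about 85 mL.min-1.g-1, with an estimated range from 50 mL.min-1.g-1 to 140 mL.min-1.g-1.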

Compound 3, intrinsic clearance in microsomes: 35 mL.min-1.g-1
For compound 3 the middle estimate is 2.4-fold (0.39 log units) above the measured one, outside the stated range (below it).
By their numbers in this assay, from the lowest: compounds 3, 1 and 2 (each within the scatter of the next).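

Among these compounds, the first measured pair for this change gives a 2.0-fold lower number from compound 2 to compound 3 (0.29 log units; within the scatter) in this assay. At this saturated chain carbon, then, replacing the group of 8 heavy atoms with the group of 10 heavy atoms does not shift clearance beyond the usual scatter, and the pair shows no rise. Nothing measured here offers an explanation for this result.

On these data alone, whether a longer chain than that of compound 3 would move the number beyond the scatter remains open. So does the effect of an amine or a carboxylic acid on that chain.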